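Shared-core cytotoxicity series: every reading at the limit

The compounds below may be only part of what the source reports. "The series", "measured", "known", "first", "only" and "open" are said of these compounds alone.

Three compounds on one core are measured. Compound 1 `C=CC1=C(C(=O)Nc2ccccc2)C(c2ccc(Cl)c(Cl)c2)OC1`, compound 2 `C=CC1=C(C(=O)Nc2ccccc2)C(c2ccc(F)cc2)OC1` and compound 3 `C=CC1=C(C(=O)NCc2ccccc2)C(c2ccc(F)cc2)OC1` are the measured set. In a functional assay on SW480 cells (Homo sapiens) for cytotoxicity, read by MTT assay, with a stated time of 24 h (on this read-out higher numbers stand for weaker inhibition and lower numbers for stronger inhibition), compound 1 gives > 100000 nM, a limit of the assay. In this assay compound 2 gives > 100000 nM, also a limit. In this assay compound 3 gives > 100000 nM, again a limit. Compound 1 differs from compound 2 by 3,4-dichlorophenyl in place of 4-fluorophenyl on a saturated ring carbon; the step is a step that the two limits leave unreadable from compound 2 to compound 1. Compound 3 differs from compound 2 by benzyl in place of phenyl on an amide-type nitrogen; the step is a step that the two limits leave unreadable from compound 2 to compound 3. All three stand at the limit of > 100000 nM in this assay, at which 3 of the 3 values shown sit.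

Compound 4 `C=CC1=C(C(=O)NCc2ccccc2)C(c2ccc(Cl)c(Cl)c2)OC1` is unmeasured and differs from compound 3 by 3,4-dichlorophenyl in place of 4-fluorophenyl on a saturated ring carbon, the same kind of change as from compound 2 to compound 1; the places differ in wording only, next to the ring atom that bears a large group against next to the ring atom that bears a group of 9 heavy atoms. The step that the limit leaves unreadable from compound 3 to compound 4 is expected to remain unreadable, resting on compound 3 sitting at the limit of > 100000 nM in this assay, at which 3 of the 3 values shown sit. Compound 4 is expected to give 150000 nM, between 60000 nM and 500000 nM, most likely reported as a limit.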

Compound 4, half-maximal inhibitory concentration: > 100000 nM
Compound 4: no number, only a limit; the forecaster's own chance of this, stated with the estimate: 85%; the middle value does not contradict the limit.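

In this assay compound 4 gives > 100000 nM, a limit. The steps from compound 3 and from compound 1 to compound 4 cannot be read: the limit of > 100000 nM in this assay, at which 4 of the 4 values shown sit.

The compounds shown leave open what numerical value any of the four compounds has, and whether any change on the shared core gives one.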